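A few compounds are considered here, and "the series" means these few. Any claim that something is new, unique, unknown or untested is made for them only; others in the source may bear on it.

In a functional assay on cells (Cancer cell lines, Homo sapiens) for inhibition (a higher number here means a weaker inhibitor of growth, a lower number a stronger inhibitor of growth), compound 1 `Cc1cn2c(/C=N/NC(=N)N)c(-c3ccsc3)nc2s1` gives 20000 nM and compound 2 `N=C(N)N/N=C/c1c(-c2ccsc2)nc2sccn12` gives 28800 nM, so the two compounds lie within the scatter of each other. Compound 3 `Cc1cc(-c2nc3sccn3c2/C=N/NC(=N)N)c(C)s1` carries 2,5-dimethylthiophen-3-yl in place of thiophen-3-yl on an aromatic carbon of the shared core, and it has not yet been measured: 2,5-dimethylthiophen-3-yl in place of thiophen-3-yl on an aromatic carbon. Among the compounds with values here, only one measured step bears on this change, and only indirectly. That step, a 1.4-fold higher number from compound 1 to compound 2 (0.16 log units; within the scatter), replaces methyl with hydrogen on an aromatic carbon of the core and leaves the thiophen-3-yl group untouched. Within the data shown here, no measured compound shows what a change to this group does, so the expectation stays loose. A small move towards a lower number, not beyond the scatter, is expected, and the estimated step is a 1.8-fold lower number from compound 2 to compound 3 (0.26 log units; within the scatter). The estimated value for compound 3 is 16000 nM, with an expected range from 5000 nM to 45000 nM.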

Compound 3, concentration for total growth inhibition: 26900 nM
The estimate for compound 3 lay 1.7-fold (0.23 log units) below the measured number, within the range that was stated.
By their numbers in this assay, from the lowest: compounds 1, 3 and 2 (each within the scatter of the next).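

In this assay, within the data shown here, this is the first measured change to the group on this aromatic carbon of the shared core, and the step to 2,5-dimethylthiophen-3-yl gives a 1.1-fold lower number from compound 2 to compound 3 (0.03 log units; within the scatter). The earlier pair spoke only to methyl against hydrogen elsewhere on the core, whereas this step shows that the two methyl groups of 2,5-dimethylthiophen-3-yl leave the number within the scatter of that for thiophen-3-yl. No measurement shown offers a reason for this result.

On these data alone, it remains open whether a group other than a thiophene at this place, such as a phenyl ring, an amine or a carboxylic acid, would move the number beyond the scatter. Also open, as far as these compounds go, is what a single methyl on the thiophene would do, or 2,5-dimethylthiophen-3-yl combined with the methyl on the core of compound 1.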